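The source may report more compounds than this note shows. Statements on the series, on what has been measured and on what is new or still open speak of the compounds shown alone.

In a functional assay on the whole organism for activation, with Mus musculus as the target, with a stated time of 60 min (on this read-out higher numbers stand for an effect only at larger amounts of compound and lower numbers for an effect already at smaller amounts), compound 2 `Nc1ccc(-c2ccc(/C=N/N3C(=O)NC(=O)C3O)o2)cc1` gives > 1000 mg/kg, which is a limit of the assay. Compound 1 `CC(=O)Nc1ccc(-c2ccc(/C=N/N3C(=O)NC(=O)C3O)o2)cc1` gives > 1000 mg/kg, also a limit. Both therefore stand at the limit of > 1000 mg/kg in this assay, at which 2 of the 2 values shown sit. Compound 3 `O=C1NC(=O)N(/N=C/c2ccc(-c3ccc([N+](=O)[O-])cc3)o2)C1O` carries nitro in place of amino on an aromatic carbon, para to a large group: nitro in place of amino on an aromatic carbon. Among the compounds with values here, the only measured step is a step that the two limits leave unreadable from compound 1 to compound 2, and it offers no size to carry over. The expected change is an at least 5.0-fold lower number from compound 2 to compound 3 (0.69 log units; beyond the scatter) in this assay, a tentative shift toward smaller doses with no measured size behind it. For compound 3 the estimate is 200 mg/kg, with an expected range of 30 mg/kg to 1000 mg/kg.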

Compound 3, dose for half-maximal effect: > 1000 mg/kg
Compound 3: no number, only a limit; the forecaster's own chance of this, stated with the estimate: 40%; middle value at least 5.0-fold (0.69 log units) from the limit.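

Within the data shown here, no step among compound 1, compound 2 and compound 3 can be read, as all three values are limits of the assay: the limit of > 1000 mg/kg in this assay, at which 3 of the 3 values shown sit. The compounds shown leave open whether acetamido, amino or nitro makes any difference to the dose for half-maximal effect.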